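The compounds below may be only part of what the source reports. "The series", "measured", "known", "first", "only" and "open" are said of these compounds alone.

Measured so far:
compound 1 `COc1cc(Cc2n[nH]c(=S)n2-c2ccc(Cl)cc2)c(S(=O)(=O)N2CCCCC2)cc1OC`: 3.31
compound 2 `COc1cc(Cc2n[nH]c(=S)n2-c2ccc(Cl)cc2)c(S(=O)(=O)N2CCCC2)cc1OC`: 2.11
compound 3 `COc1cc(Cc2n[nH]c(=S)n2-c2ccccc2)c(S(=O)(=O)N2CCCC2)cc1OC`: 2.13

These values come from a physicochemical assay for lipophilicity; on this read-out higher numbers stand for higher lipophilicity and lower numbers for lower lipophilicity. Compound 4 `COc1cc(Cc2n[nH]c(=S)n2-c2ccccc2)c(S(=O)(=O)N2CCCCC2)cc1OC` has not yet been measured in this assay. Compound 4 differs from compound 3 by piperidin-1-yl in place of pyrrolidin-1-yl on a sulfonyl sulfur. The same change stands between two measured compounds, compound 2 and compound 1, as piperidin-1-yl in place of pyrrolidin-1-yl on a sulfonyl sulfur, and there it made a number 1.20 log units higher from compound 2 to compound 1 (beyond the scatter). The two pairs sit on cores that differ by hydrogen in place of chloro on an aromatic carbon, a difference that by itself made a number 0.02 log units higher from compound 2 to compound 3 (within the scatter). The place of the ring exchange is described in the same words for both pairs, so the change from compound 3 to compound 4 is the same change as that from compound 2 to compound 1, carried onto a core that differs only in that chloro-to-hydrogen exchange.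

The step from compound 3 to compound 4 is therefore expected to be a number 1.20 log units higher from compound 3 to compound 4 (beyond the scatter), resting on a number 1.20 log units higher from compound 2 to compound 1 (beyond the scatter) and on the near-identical starting points of compound 2 and compound 3 given by a number 0.02 log units higher from compound 2 to compound 3 (within the scatter). Compound 4 is accordingly estimated at 3.33, with an expected range from 2.85 to 3.8.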

Compound 4, partition coefficient: 2.63
Compound 4: middle estimate off by 0.70 log units, on the high side, and the stated range ends above it.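

In this assay, the exchange of pyrrolidin-1-yl for piperidin-1-yl on the sulfonyl sulfur keeps its direction on the core without chloro (a number 0.50 log units higher from compound 3 to compound 4 (beyond the scatter)) but is smaller there than on the chloro core (a number 1.20 log units higher from compound 2 to compound 1 (beyond the scatter)), so between these two pairs the direction carries over and the size does not. The exchange of chloro for hydrogen also reads differently with the two rings: with piperidin-1-yl in place the step is beyond the scatter (a number 0.68 log units lower from compound 1 to compound 4 (beyond the scatter)), while with pyrrolidin-1-yl in place it is within the scatter (a number 0.02 log units higher from compound 2 to compound 3 (within the scatter)). Nothing available bears on why the two rings and the two cores combine in this way, and two pairs set no rule for any other core.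

The compounds shown leave open how morpholin-4-yl or an open-chain dimethylamino group on the sulfonyl sulfur would behave. They also leave open whether fluoro or methoxy in place of chloro would show the same dependence on the ring.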